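Branched hexyl ether on the shared chalcone core

The source may hold more compounds than are shown below. What is called first, only, known or untested is meant among the compounds shown, and "the series" means these compounds.

Compound 1 `CCCCCCOc1cccc(O)c1C(=O)/C=C/c1ccc(O)cc1` carries a straight hexyl ether on the shared core. In a functional assay on PC-3 cells (Homo sapiens) for antiproliferative activity, read by sulforhodamine B assay (on this read-out lower numbers stand for stronger inhibition of growth and higher numbers for weaker inhibition of growth), compound 1 gives > 30000 nM, which is a limit of the assay and not a number. Compound 3 `CC(C)(C)CCOc1cccc(O)c1C(=O)CCc1ccc(O)cc1` likewise gives > 30000 nM in this assay, again a limit. Compound 2 `CC(C)(C)CCOc1cccc(O)c1C(=O)/C=C/c1ccc(C(=O)O)cc1`, with a carboxylic acid in place of the phenol, gives 6500 nM in this assay. Among the values shown compound 1 thus stands at the limit of > 30000 nM in this assay, at which 2 of the 3 values shown sit; no measured step within the series can be isolated.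

Compound 4 `CC(C)CCCOc1cccc(O)c1C(=O)/C=C/c1ccc(O)cc1` remains to be measured. It differs from compound 1 by isopropyl in place of propyl on a saturated chain carbon, three bonds along the chain from an oxygen on an aromatic ring. Compound 3, which also carries a branched chain, sits at a limit. The step that the limit leaves unreadable from compound 1 to compound 4 is therefore expected to be none beyond the scatter. Compound 4 is estimated at 40000 nM in this assay, between 15000 nM and 100000 nM, with a fair chance that only a limit is reported again.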

Compound 4, concentration for 50% growth inhibition: 3600 nM
Estimate against measurement, compound 4: 11-fold (1.05 log units) above; measured number outside the range, below it.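

Within the data shown here, the step on the shared core is the first readable one: with the same atoms joined differently, isopropyl in place of propyl on a saturated chain carbon, three bonds along the chain from an oxygen on an aromatic ring, gives an at least 8.3-fold lower number from compound 1 to compound 4 (0.92 log units; beyond the scatter) in this assay. The ether chain at this place is therefore not indifferent to its shape, since the change brings a phenol-bearing chalcone off the limit with nothing else altered. Compound 1 sits at a limit of the assay, so the step has only a lower bound and its true size stays unknown: the limit of > 30000 nM in this assay, at which 2 of the 4 values shown sit.

The compounds shown leave open how far this holds for other chains, such as a longer chain carrying the same terminal branch. They also leave open whether an amine at the end of the chain would keep the value of compound 4, which is 3600 nM.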